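Furanyl nucleosides: furan-2-yl against furan-3-yl in two cores

A few compounds are considered here, and "the series" means these few. Any claim that something is new, unique, unknown or untested is made for them only; others in the source may bear on it.

Compound 3 `Cc1nc(N)c2c(-c3ccoc3)cn([C@@H]3O[C@H](CO)[C@@H](O)[C@H]3O)c2n1` carries furan-3-yl and compound 1 `Cc1nc(N)c2c(-c3ccco3)cn([C@@H]3O[C@H](CO)[C@@H](O)[C@H]3O)c2n1` carries furan-2-yl on the same core; the change is furan-2-yl in place of furan-3-yl on an aromatic carbon. In a functional assay on CCRF-CEM cells (Homo sapiens), read by MTT assay, with a stated time of 72 h (a higher number here means a weaker inhibitor, a lower number a stronger inhibitor), compound 3 gives only a limit, > 100000 nM. Compound 1 also gives only a limit in this assay, > 100000 nM. Within the data shown here, the step from compound 3 to compound 1 is therefore a step that the two limits leave unreadable from compound 3 to compound 1, and the only evidence on it is the limit of > 100000 nM in this assay, at which 2 of the 3 values shown sit. Compound 2 `COc1nc(N)nc2c1c(-c1ccoc1)cn2[C@@H]1O[C@H](CO)[C@@H](O)[C@H]1O` has a different core from compound 3; the difference between the two cores is not broken down here. In this assay compound 2 gives only a limit, > 20000 nM, which is the limit of > 20000 nM in this assay, at which 1 of the 3 values shown sits. Compound 4 `COc1nc(N)nc2c1c(-c1ccco1)cn2[C@@H]1O[C@H](CO)[C@@H](O)[C@H]1O` is the furan-2-yl analogue of compound 2, the change being (furan-2-yl in place of furan-3-yl on an aromatic carbon), the same change as from compound 3 to compound 1 at the same place. The step is expected to be a step that the limit leaves unreadable from compound 2 to compound 4, no size being readable. This expectation rests on compound 3 and compound 1, where a step that the two limits leave unreadable from compound 3 to compound 1 left both values at the limit, and on compound 2 with > 20000 nM. Compound 4 is expected to give about 60000 nM in this assay, with a range of 20000 nM to 200000 nM, and most likely only a limit.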

Compound 4, half-maximal inhibitory concentration: > 20000 nM
Compound 4 gave a limit, no number (the forecaster's own chance of this, stated with the estimate: 85%); the middle value is on the limit's open side.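

Compound 4 gives only a limit in this assay, > 20000 nM. Compound 2 also gives only a limit, > 20000 nM, so no step can be read between compound 2 and compound 4. The compounds shown leave open whether furan-2-yl in place of furan-3-yl changes potency at all in either core: all four values are limits.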